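A few compounds are considered here, and "the series" means these few. Any claim that something is new, unique, unknown or untested is made for them only; others in the source may bear on it.

Working notes on the series. In an assay on THP-1 cells for antagonist activity at Toll-like receptor 8 (Homo sapiens) (on this read-out higher numbers stand for weaker inhibition and lower numbers for stronger inhibition), compound 1 `Cc1cc(-c2cnc(OCC34CCC(N)(CC3)CC4)c(C)c2)c2cnn(C)c2n1` gives 2 nM and compound 2 `Cn1nc(-c2ccc(OC[C@H]3CC[C@H](N)CC3)c(F)c2)c2cnc(N)nc21` gives 5 nM. Compound 3 `Cc1cc(-c2ccnc3[nH]ncc23)cnc1OCC12CCC(O)(CC1)CC2` reaches only a limit of this assay, < 1 nM; the same limit is recorded as the limit of < 1 nM in this assay, at which 1 of the 3 values shown sits. Among the two values that are numbers, compound 2 stands highest, with compound 1 the nearest at a gap beyond the scatter.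

Compound 4 `Cn1nc(-c2ccc(OCC3CCNCC3)c(F)c2)c2cnc(N)nc21` differs from compound 2 by one change: piperidin-4-yl in place of 4-aminocyclohexyl on a saturated chain carbon bound to an oxygen on an aromatic ring. Going by the values given here, no measured pair carries this change, so the expectation rests on compound 2 alone. A step in this assay of modest size, if any, is expected, with either direction open and within or near the scatter, so from compound 2 to compound 4 the expected step is a 1.6-fold higher number from compound 2 to compound 4 (0.20 log units; within the scatter). For compound 4 in this assay the estimate is 8 nM, between 2 nM and 30 nM.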

Compound 4, half-maximal inhibitory concentration: 60 nM
For compound 4 the middle estimate is 7.5-fold (0.88 log units) below the measured one; the measured number lies above the stated range.
By their numbers in this assay, from the lowest: compound 1; then compound 2; then compound 4. At a limit, below all of these: compound 3.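

The place on a saturated chain carbon bound to an oxygen on an aromatic ring proves sensitive: in this assay, piperidin-4-yl in place of 4-aminocyclohexyl gives a 12-fold higher number from compound 2 to compound 4 (1.08 log units; beyond the scatter). Going by these compounds alone, this is the first one-place step, and it is large although the counted donors, acceptors and net charge stay the same. Nothing measured here accounts for the step.

Open, as far as these compounds go, is whether a pyrrolidine or a piperidine with a methyl group on its nitrogen would behave like piperidin-4-yl at this place. Also open, from the compounds shown here alone, is whether the step carries over to the core of compound 1.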